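Removing the Carboxy Group from a Platelet Inhibitor

A few compounds are considered here, and "the series" means these few. Any claim that something is new, unique, unknown or untested is made for them only; others in the source may bear on it.

The series centres on compound 1 `O=C(O)c1ccc(S(=O)(=O)N[C@@H](CNC(=O)c2ccc(N3CCC(NC4=NCCCN4)CC3)c(F)c2)C(=O)O)cc1`, built around an amino acid bearing a sulfonamide on one side and an amide on the other. For the measured compounds named here, in a functional assay on a cell-free system (Platelet, plasma, Homo sapiens) for inhibition (a higher number here means a weaker inhibitor, a lower number a stronger inhibitor), compound 1 gives 930 nM, which is the highest of the two numbers measured so far, meaning it is the weaker of the two inhibitors. Going by the values given here, its only measured neighbour is compound 2 `O=C(NC[C@H](NS(=O)(=O)c1ccccc1)C(=O)O)c1ccc(N2CCC(NC3=NCCCN3)CC2)c(O)c1`, which differs in more than one place and in this assay gives 170 nM, a lower number that lies beyond the usual scatter.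

Compound 3 `O=C(NC[C@H](NS(=O)(=O)c1ccccc1)C(=O)O)c1ccc(N2CCC(NC3=NCCCN3)CC2)c(F)c1` is the direct partner of compound 1. The change is hydrogen in place of carboxy on an aromatic carbon. Nothing else in the molecule moves.

Among the compounds with values here, no measured pair shows this exact change, so the expectation rests on the values of compound 1 and compound 2 alone. Because compound 2 with its simpler phenylsulfonyl gives 170 nM, a modest drop in the number, toward a stronger inhibitor, is expected, though possibly within the scatter. The estimated step is a 2.3-fold lower number from compound 1 to compound 3 (0.37 log units; beyond the scatter). Compound 3 is expected to give 400 nM, within a range from 130 nM to 1200 nM.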

Compound 3, half-maximal inhibitory concentration: 37 nM
Estimate against measurement, compound 3: 11-fold (1.03 log units) above; the whole stated range lies above it.
By their numbers in this assay, from the lowest: compound 3; then compound 2; then compound 1.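

In this assay, replacing the carboxy of the 4-carboxyphenyl group with hydrogen, which leaves a plain phenylsulfonyl, gives a 25-fold lower number from compound 1 to compound 3 (1.40 log units; beyond the scatter), so the aromatic carbon para to a large group turns out to be a place where this single change has a large effect on inhibition. For the compounds shown here, the fluoro and hydroxy groups on the other aromatic ring also matter, though the step is modest: fluoro in place of hydroxy gives a 4.6-fold lower number from compound 2 to compound 3 (0.66 log units; beyond the scatter), and the fluoro form is the one with the lowest number of the three. Nothing measured here bears on the reason for either step.

Going by these compounds, it remains open whether the carboxy itself is what weakens inhibition at this carbon or whether any group there would do the same, and a methyl, a methoxy or an amine on the same carbon would help to separate these two readings. On these data alone, it is also open how far the fluoro result extends, since a chloro or a methoxy in that place would show whether the hydroxy-to-fluoro step is specific to fluoro.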